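Swapping a Nitro for Trifluoromethyl on a Shared Core

A few compounds are considered here, and "the series" means these few. Any claim that something is new, unique, unknown or untested is made for them only; others in the source may bear on it.

Three related compounds have been tested in a functional assay on MCF7 cells (Homo sapiens) for cytotoxicity, read by MTT assay, with a stated time of 72 h; a lower number here means a stronger inhibitor, a higher number a weaker inhibitor. Compound 1 `COc1ccccc1Nc1nc(SCc2ccc(C(F)(F)F)cc2)nc2ccccc12` reaches only the limit of this assay, > 50000 nM. Compound 2 `O=[N+]([O-])c1cccc(Nc2nc(SCc3ccc(C(F)(F)F)cc3)nc3ccccc23)c1` likewise stops at the limit, > 50000 nM. Going by the values given here, compound 3 `O=[N+]([O-])c1ccc(Nc2nc(SCc3ccc(C(F)(F)F)cc3)nc3ccccc23)cc1` is the one compound with a real number, 17900 nM, so it stands as the sole readable point. The steps of an at least 2.7-fold lower number from compound 1 to compound 3 (0.44 log units; beyond the scatter) and an at least 2.7-fold lower number from compound 2 to compound 3 (0.44 log units; beyond the scatter) both lead to it, and their sizes can be read only as minimum sizes because of the limit of > 50000 nM in this assay, at which 2 of the 3 values shown sit.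

Compound 4 `FC(F)(F)c1ccc(CSc2nc(Nc3ccc(C(F)(F)F)cc3)c3ccccc3n2)cc1` differs from compound 3 in one place: trifluoromethyl in place of nitro on an aromatic carbon. Among the compounds with values here, no measured step turns a nitro into a trifluoromethyl, so the two steps just named show only that the 4-nitrophenyl went with the lowest number seen; its removal is expected to raise the number in this assay, a step of a 2.0-fold higher number from compound 3 to compound 4 (0.29 log units; within the scatter). Compound 4 is therefore estimated at 35000 nM, within 12000 nM to 100000 nM.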

Compound 4, half-maximal inhibitory concentration: 5100 nM
Estimate against measurement, compound 4: 6.9-fold (0.84 log units) above; the measured number lies below the stated range.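

Removing the nitro group did not raise the number as expected: in this assay, trifluoromethyl in its place gives a 3.5-fold lower number from compound 3 to compound 4 (0.55 log units; beyond the scatter). So, in this pair, the nitro group is not needed for the activity seen. The other two comparisons read an at least 9.8-fold lower number from compound 2 to compound 4 (0.99 log units; beyond the scatter) and an at least 9.8-fold lower number from compound 1 to compound 4 (0.99 log units; beyond the scatter), and both are minimum sizes: the limit of > 50000 nM in this assay, at which 2 of the 4 values shown sit.

As far as these compounds go, whether an amine or a carboxylic acid at this place would lower the number further stays open. So does whether trifluoromethyl in place of the nitro of compound 2 would do the same.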